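The source may report more compounds than this note shows. Statements on the series, on what has been measured and on what is new or still open speak of the compounds shown alone.

In a functional assay on MIA PaCa-2 cells (Homo sapiens) for inhibition, read by MTT assay, with a stated time of 7 days (a lower number here means a stronger inhibitor, a higher number a weaker inhibitor), three compounds sharing one core have been measured: compound 1 `CCN(CC)S(=O)(=O)c1ccc(S(=O)(=O)N2CCC[C@@H](C(=O)N3CCC(O)CC3)C2)cc1` gives 870 nM, compound 2 `CCN(CC)S(=O)(=O)c1ccc(S(=O)(=O)N2CCC[C@@H](C(=O)N3CCC(OC)CC3)C2)cc1` gives 140 nM, and compound 3 `CCN(CC)S(=O)(=O)c1ccc(S(=O)(=O)N2CCC[C@@H](C(=O)N3CCOCC3)C2)cc1` gives 350 nM. Compound 3 thus stands second highest of the three, separated from its neighbours by a 2.5-fold lower number from compound 1 to compound 3 (0.40 log units; beyond the scatter) and by a 2.5-fold higher number from compound 2 to compound 3 (0.40 log units; beyond the scatter), while a 6.2-fold lower number from compound 1 to compound 2 (0.79 log units; beyond the scatter) links the other two. Compound 4 `CCN(CC)S(=O)(=O)c1ccc(S(=O)(=O)N2CCC[C@@H](C(=O)NC3CCOCC3)C2)cc1` differs from compound 3 by (oxan-4-yl)amino in place of morpholin-4-yl on a carbonyl carbon. Within the data shown here, both steps reaching compound 3 change the group on the carbonyl carbon and are modest, but neither replaces morpholin-4-yl with an amino-linked ring, so no measured step matches this change and its direction is open. The step of a 1.1-fold higher number from compound 3 to compound 4 (0.06 log units; within the scatter) is therefore expected to be small, possibly within the scatter. In this assay compound 4 is estimated at 400 nM, between 120 nM and 1400 nM.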

Compound 4, half-maximal inhibitory concentration: 3770 nM
For compound 4 the middle estimate is 9.4-fold (0.97 log units) below the measured one, outside the stated range (above it).
By their numbers in this assay, from the lowest: compound 2; then compound 3; then compound 1; then compound 4.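

In this assay the group on the carbonyl carbon proved more sensitive than the earlier modest steps suggested, with an 11-fold higher number from compound 3 to compound 4 (1.03 log units; beyond the scatter) for the change from morpholin-4-yl to (oxan-4-yl)amino. The same group also gives a 27-fold higher number from compound 2 to compound 4 (1.43 log units; beyond the scatter) and a 4.3-fold higher number from compound 1 to compound 4 (0.64 log units; beyond the scatter) and so places compound 4 above all three others. Nothing given here accounts for these steps. The compounds shown leave open whether the added amide hydrogen or the altered ring matters more, as both change together. A methyl(oxan-4-yl)amino group would separate them.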